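Ring swap at the aryl ether on two cores

The compounds below may be only part of what the source reports. "The series", "measured", "known", "first", "only" and "open" are said of these compounds alone.

Measured values in a functional assay (aorta) with Rattus norvegicus as the target, in the presence of a further agent that is not named here; a higher number here means that more compound is needed for the effect, a lower number that less compound is needed:

compound 1 `COC(=O)C1=C(C)N=C(C)/C(=C(/O)OC)C1c1cccc(OCc2no[n+]([O-])c2C(N)=O)c1` gives 710 nM
compound 2 `COC(=O)C1=C(C)N=C(C)/C(=C(/O)OC)C1c1ccccc1OCc1no[n+]([O-])c1C(N)=O` gives 550 nM
compound 3 `COC(=O)C1=C(C)N=C(C)/C(=C(/O)OC)C1c1cccc(OCc2nonc2C#N)c1` gives 310 nM

Compound 1 and compound 2 share the same atoms joined differently; the difference between the two cores is not broken down here. What compound 2 shows against compound 1 lies within the scatter, and what it shows against compound 3 lies within the scatter as well, so no ordering among these three is claimed.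

One change is seen in a measured pair: from compound 1 to compound 3, (a group of 7 heavy atoms (3 carbon, 3 nitrogen, 1 oxygen; one five-membered aromatic ring with 3 hetero atoms) in place of a group of 9 heavy atoms (3 carbon, 3 nitrogen, 3 oxygen; one five-membered aromatic ring with 3 hetero atoms), on a saturated chain carbon bound to an oxygen on an aromatic ring). In this assay it made a 2.3-fold lower number from compound 1 to compound 3 (0.36 log units; beyond the scatter).

Compound 4 `COC(=O)C1=C(C)N=C(C)/C(=C(/O)OC)C1c1ccccc1OCc1nonc1C#N` has not yet been measured in this assay. It carries the same change on the core of compound 2: from compound 2 to compound 4, (a group of 7 heavy atoms (3 carbon, 3 nitrogen, 1 oxygen; one five-membered aromatic ring with 3 hetero atoms) in place of a group of 9 heavy atoms (3 carbon, 3 nitrogen, 3 oxygen; one five-membered aromatic ring with 3 hetero atoms), on a saturated chain carbon bound to an oxygen on an aromatic ring). The two places are described in the same words, so this is the same change, seen here for the second time.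

The expectation for compound 4 rests on one measured step only, and the second core is a different setting, so the estimate is held wide. The step from compound 2 to compound 4 is expected to be about a 2.3-fold lower number from compound 2 to compound 4 (0.36 log units; beyond the scatter), because the same change gave a 2.3-fold lower number from compound 1 to compound 3 (0.36 log units; beyond the scatter). Starting from compound 2 with 550 nM, compound 4 is estimated at 240 nM, with a range from 120 nM to 480 nM.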

Compound 4, half-maximal effective concentration: 6.6 nM
Compound 4: middle estimate off by 36-fold (1.56 log units), on the high side; measured number outside the range, below it.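

In this assay, placing the 4-cyano-1,2,5-oxadiazol-3-yl group on the saturated chain carbon bound to an oxygen on an aromatic ring gives an 83-fold lower number from compound 2 to compound 4 (1.92 log units; beyond the scatter), so less compound is needed for the effect after the change. The direction therefore agrees on the two cores, but the size does not: the same change on two cores in this assay, a 2.3-fold lower number (0.36 log units; beyond the scatter) from compound 1 to compound 3 and an 83-fold lower number (1.92 log units; beyond the scatter) from compound 2 to compound 4, 36-fold (1.56 log units) apart, beyond the scatter of two such steps. In this series the change can be carried from one core to another as a direction at most, not as a fixed increment, and two pairs do not show which size is typical, what sets the gap between them, or whether the same direction would hold on any further core.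

The compounds shown leave open which part of the exchanged group matters, since the heavy-atom count, the hydrogen-bond donor count and the triple bond all change together in a single step. A carboxylic acid, a methyl ester or a simple amide in place of the nitrile on the 1,2,5-oxadiazol-3-yl ring, tested on both cores, would begin to separate these features and show whether the large step on the second core belongs to the nitrile itself.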